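The source may report more compounds than this note shows. Statements on the series, on what has been measured and on what is new or still open speak of the compounds shown alone.

Compound 2 `CC(C)c1ccc(S(=O)(=O)NCCCCCCNCc2ccc(Br)cc2)cc1`: 5730 nM
Compound 1 `Cc1ccc(C)c(S(=O)(=O)NCCCCCCNCc2ccc(Br)cc2)c1`: 12000 nM

In a functional assay on MIA PaCa-2 cells (Homo sapiens) for inhibition, read by MTT assay, with a stated time of 72 h (a lower number here means a stronger inhibitor of growth, a higher number a weaker inhibitor of growth), compound 2 gives 5730 nM and compound 1 gives 12000 nM, so compound 2 has the lowest of the two numbers, with compound 1 a step away: a 2.1-fold lower number from compound 1 to compound 2 (0.32 log units; beyond the scatter). Compound 3 `O=S(=O)(NCCCCCCNCc1ccc(Br)cc1)c1ccccc1F` has not been measured. It differs from compound 2 in one place: 2-fluorophenyl in place of 4-isopropylphenyl on a sulfonyl sulfur. Within the data shown here, the only measured step, a 2.1-fold lower number from compound 1 to compound 2 (0.32 log units; beyond the scatter), also swaps one aryl group for another on the same sulfonyl sulfur, and it shows that such a swap can shift the number by a modest amount in either direction; it does not involve a 2-fluorophenyl group, so it bears on the new change only loosely. Compound 3 is therefore expected to land a modest step from compound 2, most likely toward the higher number of compound 1, as a 1.7-fold higher number from compound 2 to compound 3 (0.24 log units; within the scatter). The estimate for compound 3 in this assay is 10000 nM, within a range of 4000 nM to 25000 nM.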

Compound 3, concentration for 50% growth inhibition: 13300 nM
The estimate for compound 3 lay 1.3-fold (0.12 log units) below the measured number; measured number inside the range.
By their numbers in this assay, from the lowest: compound 2; then compounds 1 and 3 (each within the scatter of the next).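

Swapping the 4-isopropylphenyl group for 2-fluorophenyl on the sulfonyl sulfur gives a 2.3-fold higher number from compound 2 to compound 3 (0.37 log units; beyond the scatter) in this assay, a second step from compound 2 that is beyond the scatter and again goes toward a higher number. The other two aryl groups cannot be told apart here, as a 1.1-fold higher number from compound 1 to compound 3 (0.04 log units; within the scatter) shows, so among these three compounds only compound 2 stands out, with the lowest number. No measurement of any property of these compounds speaks to what lies behind this difference.

The three groups differ both in their substituents and in where those sit on the ring, so a 4-fluorophenyl or 2-isopropylphenyl group would be needed to separate the two. Also open, from the compounds shown here alone, is how a non-aromatic group such as cyclohexyl on the sulfonyl sulfur, or a shorter chain in the core, would change the number.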